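This account rests on a few compounds, and the source may have more. Where it says the series, first, only, none or still open, it means among the compounds named here.

Working notes on the series in an ADME assay on NIH3T3 cells (Mus musculus) for cytotoxicity, read by MTT assay, with a stated time of 72 h; on this read-out higher numbers stand for weaker inhibition and lower numbers for stronger inhibition. Of the compounds shown here, three have been read. Compound 1, `COc1ccc(/C=C/c2cc(C)n[nH]2)cc1`, gives 19900 nM in this assay. Compound 3, `CC(=O)/C=C(O)/C=C/c1ccc(O)c(O)c1`, gives 51200 nM in this assay. Compound 2, `COc1cc(/C=C/c2cc(C)no2)ccc1O`, returns no number in this assay but only a limit, > 100000 nM. Its reading sits at the limit of > 100000 nM in this assay, at which 1 of the 3 values shown sits, so on the numbers shown compound 2 stands as the one member of the set for which inhibition was not quantified; it is the weak end of what this assay can report.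

Compound 4, `Cc1cc(/C=C/c2ccc(O)cc2)on1`, is not yet measured. It differs from compound 2 in a single place: hydrogen in place of methoxy on an aromatic carbon. Among the compounds with values here, no pair of measured compounds differs in this way, so no measured step guides the size of the move in this assay. The change is small in atom count, and compound 2 itself only reached the limit. The step of an at least 1.2-fold lower number from compound 2 to compound 4 (0.09 log units; that floor lies within the scatter) is therefore expected to be none beyond the scatter or at most a modest move toward stronger inhibition. Compound 4 is expected to give 80000 nM in this assay, with a range from 25000 nM to 100000 nM, and a real chance that this assay again reports only a limit for compound 4.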

Compound 4, half-maximal inhibitory concentration: 88500 nM
The estimate for compound 4 lay 1.1-fold (0.04 log units) below the measured number, and the stated range covers the measured number.
By their numbers in this assay, from the lowest: compound 1; then compounds 3 and 4 (each within the scatter of the next). At a limit, above all of these: compound 2.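

In this assay, the series now has its first reading of hydrogen in place of methoxy on an aromatic carbon ortho to a hydroxy group, and that reading is an at least 1.1-fold lower number from compound 2 to compound 4 (0.05 log units; that floor lies within the scatter). The entry for compound 2 is a limit and not a number: the limit of > 100000 nM in this assay, at which 1 of the 4 values shown sits. The step therefore has only a floor, which does not establish a move beyond the scatter but does not exclude a larger one. With hydrogen at this place compound 4 gives a quantified reading of 88500 nM.

From the compounds shown here alone, what an amine, a carboxylic acid or a longer alkoxy chain on this aromatic carbon would do to the reading remains open, since compounds 2 and 4 show only methoxy and hydrogen here. Going by these compounds, compound 1 and compound 3 each differ from compound 2 and compound 4 in more than one place, so they give no second reading of this change, and whether it would act the same way on another core also remains open.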